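From 3-methoxyphenyl to 4-methoxyphenyl on a carbonyl carbon

This account rests on a few compounds, and the source may have more. Where it says the series, first, only, none or still open, it means among the compounds named here.

In a functional assay on MDA-MB-468 cells (Homo sapiens) for antiproliferative activity, read by MTT assay, with a stated time of 48 h (a lower number here means a stronger inhibitor, a higher number a weaker inhibitor), compound 2 `COc1cccc(C(=O)Nc2cc3cnc(NCCN(C)C)cc3n(C)c2=O)c1` gives 17400 nM. Compound 1 `CN(C)CCNc1cc2c(cn1)cc(NC(=O)c1ccc(N)cc1)c(=O)n2C` gives 20400 nM, so these two share the low end of the numbers shown. The step linking them, with 3-methoxyphenyl in place of 4-aminophenyl, is a 1.2-fold lower number from compound 1 to compound 2 (0.07 log units; within the scatter).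

Compound 3 `CC(=O)Nc1cc2cnc(NCCN(C)C)cc2n(C)c1=O`, with methyl on the carbonyl carbon, gives > 100000 nM, which is a limit of the assay. Methyl in place of the ring-bearing groups gives an at least 4.9-fold higher number from compound 1 to compound 3 (0.69 log units; beyond the scatter) and an at least 5.7-fold higher number from compound 2 to compound 3 (0.75 log units; beyond the scatter).

Compound 4 `COc1ccc(C(=O)Nc2cc3cnc(NCCN(C)C)cc3n(C)c2=O)cc1` differs from compound 2 in a single place: 4-methoxyphenyl in place of 3-methoxyphenyl on a carbonyl carbon. It has 4-methoxyphenyl in place of 3-methoxyphenyl on a carbonyl carbon. Going by the values given here, compound 4 thus keeps an aromatic ring there, and the one measured exchange of one such ring group for another, a 1.2-fold lower number from compound 1 to compound 2 (0.07 log units; within the scatter), stayed small. The step to methyl does not apply to this change. No step beyond the scatter is therefore expected in this assay, and the expected step is a 1.0-fold higher number from compound 2 to compound 4 (0.01 log units; within the scatter).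

The estimate for compound 4 is 18000 nM, with an expected range from 8000 nM to 40000 nM.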

Compound 4, half-maximal inhibitory concentration: 15700 nM
Compound 4: the middle estimate sits 1.1-fold (0.06 log units) above what was measured; low and high end bracket the measured number.
By their numbers in this assay, from the lowest: compounds 4, 2 and 1 (each within the scatter of the next). At a limit, above all of these: compound 3.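

In this assay, 4-methoxyphenyl in place of 3-methoxyphenyl on the carbonyl carbon gives a 1.1-fold lower number from compound 2 to compound 4 (0.04 log units; within the scatter), so this exchange within one substituent type leaves the number within the scatter. Methoxy in place of amino on an aromatic carbon gives a 1.3-fold lower number from compound 1 to compound 4 (0.11 log units; within the scatter), and these two groups cannot be told apart here either. The separation from methyl now holds for a third aromatic group, at an at least 6.3-fold lower number from compound 3 to compound 4 (0.80 log units; beyond the scatter), although the value of compound 3 is a limit of the assay and not a number: the limit of > 100000 nM in this assay, at which 1 of the 4 values shown sits.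

As far as these compounds go, it remains open whether the aromatic ring itself is what separates compounds 1, 2 and 4 from compound 3, and a cyclohexyl group or a butyl chain on that carbonyl carbon would test this. From the compounds shown here alone, how a carboxylic acid in place of the methoxy would read also remains open.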